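Notes on the triazole ether series: compound 3 to compound 4

The source may hold more compounds than are shown below. What is called first, only, known or untested is meant among the compounds shown, and "the series" means these compounds.

Going by the values given here, compound 1 `CCOC(=O)C1=Cc2ccccc2OC1(OCc1cn(CC(=O)Nc2ccc(C)cc2)nn1)C(F)(F)F` is the only member with a number in a functional assay on A549 cells (Homo sapiens) for inhibition, read by MTT assay, with a stated time of 24 h; on this read-out lower numbers stand for stronger inhibition and higher numbers for weaker inhibition: compound 1 gives 54300 nM. Compound 2 `CCOC(=O)C1=Cc2ccccc2OC1(OCc1cn(-c2ccccc2)nn1)C(F)(F)F` reaches only a limit, and in this assay compound 2 gives > 150000 nM. Compound 3 `CCCCCCCCn1cc(COC2(C(F)(F)F)Oc3ccccc3C=C2C(=O)OCC)nn1` likewise reaches only a limit, and in this assay compound 3 gives > 150000 nM. Compound 3 thus stands at the top of what is shown, a position it shares with compound 2 because of the limit of > 150000 nM in this assay, at which 2 of the 3 values shown sit. The steps of an at least 2.7-fold higher number from compound 1 to compound 2 (0.44 log units; beyond the scatter) and an at least 2.7-fold higher number from compound 1 to compound 3 (0.44 log units; beyond the scatter) both weaken and are at least modest; the step that the two limits leave unreadable from compound 2 to compound 3 cannot be read.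

Compound 4 `CCOC(=O)C1=Cc2ccccc2OC1(OCc1cn(CC(=O)Nc2ccc(I)cc2Cl)nn1)C(F)(F)F` differs from compound 3 by (2-chloro-4-iodophenyl)carbamoyl in place of heptyl on a saturated chain carbon bound to an aromatic nitrogen. This undoes the change behind an at least 2.7-fold higher number from compound 1 to compound 3 (0.44 log units; beyond the scatter), with (2-chloro-4-iodophenyl)carbamoyl entering rather than (4-methylphenyl)carbamoyl, so a return toward the region of compound 1 is expected. The expected step is an at least 3.0-fold lower number from compound 3 to compound 4 (0.47 log units; beyond the scatter), downward. Compound 4 is accordingly estimated at 50000 nM, within 15000 nM to 150000 nM.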

Compound 4, half-maximal inhibitory concentration: 22300 nM
Compound 4: middle estimate off by 2.2-fold (0.35 log units), on the high side, within the range that was stated.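

In this assay, the ((2-chloro-4-iodophenyl)carbamoyl)methyl group on the aromatic nitrogen gives a measured number with a second aryl group on the amide-type nitrogen, with an at least 6.7-fold lower number from compound 3 to compound 4 (0.82 log units; beyond the scatter) and an at least 6.7-fold lower number from compound 2 to compound 4 (0.82 log units; beyond the scatter). Both steps start from a limit of the assay and so are open-ended: the limit of > 150000 nM in this assay, at which 2 of the 4 values shown sit. Going by these compounds alone, the aryl group itself also counts at this place, a point the earlier compounds could not show, since 2-chloro-4-iodophenyl in place of 4-methylphenyl on the amide-type nitrogen gives a 2.4-fold lower number from compound 1 to compound 4 (0.39 log units; beyond the scatter).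

The compounds shown do not separate the chlorine from the iodine in that last change. Also open, going by these compounds, is how an amine or a carboxylic acid in place of the 2-chloro-4-iodophenyl group would read.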